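Swapping the aryl group on the amide carbonyl

A few compounds are considered here, and "the series" means these few. Any claim that something is new, unique, unknown or untested is made for them only; others in the source may bear on it.

Measured so far:
- compound 1 `O=C(/C=C/c1cccc(NC(=O)c2ccccc2Cl)c1)c1nc2ccccc2[nH]1` gives 4570 nM
- compound 2 `Cc1cccc(C(=O)Nc2cccc(/C=C/C(=O)c3nc4ccccc4[nH]3)c2)c1` gives 5590 nM

Both compounds were tested in a functional assay on MCF7 cells (Homo sapiens) for antiproliferative activity, read by MTT assay, with a stated time of 48 h (a higher number here means a weaker inhibitor, a lower number a stronger inhibitor), which tracks how strongly each one holds back the growth of the cells. Among the compounds with values here, compound 2 stands at the higher of the two numbers, but its only neighbour is compound 1, and the step of a 1.2-fold higher number from compound 1 to compound 2 (0.09 log units; within the scatter) lies within the scatter, so the two cannot be told apart on these data.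

Compound 3 `COc1ccc(C(=O)Nc2cccc(/C=C/C(=O)c3nc4ccccc4[nH]3)c2)cc1` carries a single change: 4-methoxyphenyl in place of 3-methylphenyl on a carbonyl carbon. Within the data shown here, the one measured step that bears on this position is a 1.2-fold higher number from compound 1 to compound 2 (0.09 log units; within the scatter), where the aryl group on the same carbonyl carbon was exchanged and the number stayed within the scatter. Among the measured compounds shown here, with only that precedent, no step beyond the scatter is expected in this assay in either direction, and the uncertainty is wide because a single step is all there is to go on.

Compound 3 is therefore expected to give 5200 nM, with a plausible range of 2300 nM to 12000 nM. The step from compound 2 to compound 3 that this estimate implies is a 1.1-fold lower number from compound 2 to compound 3 (0.03 log units; within the scatter).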

Compound 3, half-maximal inhibitory concentration: 20100 nM
Compound 3: the middle estimate sits 3.9-fold (0.59 log units) below what was measured, and the stated range ends below it.
By their numbers in this assay, from the lowest: compounds 1 and 2 (each within the scatter of the next); then compound 3.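

Seen from compound 1 and compound 2 alone, the aryl group on this carbonyl carbon looked as if it could be exchanged with little consequence. In this assay the move to 4-methoxyphenyl gives a 3.6-fold higher number from compound 2 to compound 3 (0.56 log units; beyond the scatter) and a 4.4-fold higher number from compound 1 to compound 3 (0.64 log units; beyond the scatter) and so the number at this position can shift beyond the scatter, although both steps are modest. Compound 3 therefore stands apart from the other two compounds, whose 2-chlorophenyl and 3-methylphenyl groups remain within the scatter of each other, and nothing measured alongside these compounds accounts for the difference.

With one compound carrying the methoxy group, these data cannot separate the effect of that group from the effect of where it sits on the ring, and a 3-methoxyphenyl or a 4-methylphenyl group would help to tell the two apart. Also open, from the compounds shown here alone, is how this position would respond to quite different groups on the ring, such as an amine or a carboxylic acid, and whether any of them would give a lower number than compound 1 and compound 2.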